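This account rests on a few compounds, and the source may have more. Where it says the series, first, only, none or still open, it means among the compounds named here.

Of the compounds shown here, three have been measured in an assay on CHO cells for displacement of a labelled ligand from adenosine receptor A1 (Homo sapiens), read by scintillation counting, with a stated time of 60 min, tested at 10 uM; on this read-out higher numbers stand for more inhibition at the one concentration tested (going by the name of the read-out) and lower numbers for less inhibition. Compound 1 `O=C(O)CNC(=O)c1cc2ccccc2oc1=O` gives 1%, compound 2 `COc1cccc2c1OC(C)(O)C(C(C)=O)=C2` gives 6%, and compound 3 `O=C(NC1CCCC1)c1cc2ccccc2oc1=O` gives 16%. Compound 3 thus has the top number of the three, although the gap to compound 2 lies within the scatter of repeated measurements; only its distance from compound 1 is clear, as the step of a number 15 percentage points higher from compound 1 to compound 3 (beyond the scatter) shows, where cyclopentyl took the place of carboxymethyl on the amide-type nitrogen.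

Compound 4 `O=C(NCCCO)c1cc2ccccc2oc1=O` takes the next step from compound 3: 3-hydroxypropyl in place of cyclopentyl on an amide-type nitrogen. Among the measured compounds shown here, the one measured step that bears on this change is that from compound 1 to compound 3, in which the same cyclopentyl entered and a chain bearing oxygen left, and the number rose modestly. The present change runs in the opposite sense, with cyclopentyl leaving and a chain bearing oxygen entering, so a modest fall in this assay is expected, though not necessarily one that fully undoes the earlier rise. Compound 4 is therefore estimated at 7%, with a range from 0% to 18%, meaning an expected step of a number 9 percentage points lower from compound 3 to compound 4 (within the scatter).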

Compound 4, a percentage reported as inhibition, at one concentration (the size of the read-out at that concentration, not a potency): 24%
The estimate for compound 4 lay 17 percentage points below the measured number; measured number above the stated range.
By their numbers in this assay, from the lowest: compounds 1, 2, 3 and 4 (each within the scatter of the next, the first and the last beyond it).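

On this amide-type nitrogen, a five-membered ring of carbon only is not needed to hold the read-out at its level: in this assay, the open 3-hydroxypropyl chain gives a number 8 percentage points higher from compound 3 to compound 4 (within the scatter). A chain bearing oxygen does not in itself bring the low number of compound 1, as a number 23 percentage points higher from compound 1 to compound 4 (beyond the scatter) shows, with 2-hydroxyethyl in place of carboxy on the saturated chain carbon bound to the amide-type nitrogen. No measurement at hand accounts for either step.

On these data alone, whether the hydroxyl matters at all stays open, and a plain propyl chain or a chain ending in an amine on the same nitrogen would test that. A longer chain, or a cyclopentyl ring carrying a hydroxyl, would show whether chain length or the ring decides the number.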